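The compounds below may be only part of what the source reports. "The series", "measured", "known", "first", "only" and "open" are said of these compounds alone.

In a functional assay (plasma) for inhibition, with Oryctolagus cuniculus as the target (a higher number here means a weaker inhibitor, a lower number a stronger inhibitor), compound 1 (`Cc1ccc(S(=O)(=O)N[C@H]2C3CC[C@H](C3)[C@@H]2C/C=C\CCCC(=O)O)cc1`) gives 500 nM. Compound 2 (`O=C(O)CCC/C=C\C[C@H]1[C@@H]2CCC(C2)[C@@H]1NS(=O)(=O)c1ccc(O)cc1`) gives 500 nM, level with compound 1, its nearest neighbour. Compound 3 (`COc1ccc(S(=O)(=O)N[C@H]2C3CC[C@H](C3)[C@@H]2C/C=C\CCCC(=O)O)cc1`) carries methyl in place of hydrogen on an oxygen on an aromatic ring, taking hydroxy to methoxy (methyl in place of hydrogen on an oxygen on an aromatic ring). Going by the values given here, the only measured step that bears on this change, hydroxy in place of methyl on an aromatic carbon, showed no change at the digits printed from compound 1 to compound 2 (within the scatter). On that single step, no shift beyond the scatter is expected in this assay, and the expected step is no change at the digits printed from compound 2 to compound 3 (within the scatter). The estimate for compound 3 is 500 nM, with an expected range of 200 nM to 1200 nM.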

Compound 3, half-maximal inhibitory concentration: 1700 nM
Compound 3: middle estimate off by 3.4-fold (0.53 log units), on the low side; the measured number lies above the stated range.
By their numbers in this assay, from the lowest: compounds 1 and 2 (each within the scatter of the next); then compound 3.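

In this assay, hydroxy to methoxy brings a 3.4-fold higher number from compound 2 to compound 3 (0.53 log units; beyond the scatter), and methoxy in place of methyl on the aromatic carbon brings a 3.4-fold higher number from compound 1 to compound 3 (0.53 log units; beyond the scatter). This place on the ring therefore does respond to the group it carries, although methyl and hydroxy could not be told apart: among these three groups, methoxy alone stands apart, as the weaker inhibitor. Nothing given here accounts for this shift. The compounds shown leave open how a chlorine atom or an amine would read at this place, and whether an ethoxy group would carry the step further.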